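The source may report more compounds than this note shows. Statements on the series, on what has been measured and on what is new or still open speak of the compounds shown alone.

Of the compounds shown here, three have been tested in an ADME assay on MDBK cells (Bos taurus) for cytotoxicity, read by MTT assay, with a stated time of 96 h (a higher number here means that more compound is tolerated, a lower number that less compound is tolerated), and a fourth awaits its turn. Compound 1 `Cn1c(-c2ccc([N+](=O)[O-])cc2)nc2cc(C(F)(F)F)ccc21` reaches only the limit of the measurement: in this assay compound 1 gives > 100000 nM, a limit rather than a number. For the measured compounds named here, compound 2 `O=C(CN1CCCC1)Nc1ccc(-c2nc3cc(Cl)c(Cl)cc3[nH]2)cc1` is the one compound with a measured figure, as in this assay compound 2 gives 16000 nM. Compound 3 `CC(=O)Nc1ccc(-c2nc3cc([N+](=O)[O-])ccc3[nH]2)cc1` also stops at the limit, since in this assay compound 3 gives > 100000 nM, which is a limit and not a number. Compound 3 therefore stands with compound 1 at the top end of what the measurement can report, a point underlined by the limit of > 100000 nM in this assay, at which 2 of the 3 values shown sit.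

Compound 4 `CC(=O)Nc1ccc(-c2nc3ccccc3[nH]2)cc1` differs from compound 3 in one place: hydrogen in place of nitro on an aromatic carbon. Going by the values given here, no step between two measured compounds is available to calibrate this change. Compound 3 is already at the limit, so the step from it to compound 4 is expected to be small or none beyond the scatter, a number no higher from compound 3 to compound 4 (the limit leaves the size open). Compound 4 is therefore estimated to give 100000 nM, within a range from 30000 nM to 300000 nM.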

Compound 4, half-maximal cytotoxic concentration: > 100000 nM
Compound 4 gave a limit, no number (the forecaster's own chance of this, stated with the estimate: 70%); the middle value sits exactly at the limit.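

Compound 3 and compound 4 both stop at a limit in this assay, and no step between them can be read: the limit of > 100000 nM in this assay, at which 3 of the 4 values shown sit.

The compounds shown leave open what hydrogen in place of nitro does to how much compound these cells tolerate.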